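The source may report more compounds than this note shows. Statements on the series, on what has been measured and on what is new or still open speak of the compounds shown alone.

Measured so far:
compound 1 `CN(C)CCCCCCCCCOc1ccc2oc(-c3ccccc3)cc(=O)c2c1` — 334 nM
compound 2 `CN(C)CCCCCCCCCCOc1ccc2oc(-c3ccccc3)cc(=O)c2c1` — 297 nM

Two compounds share one core and differ only in the length of the saturated chain that links an oxygen on the aromatic ring to a dimethylamino group. In an assay on isolated protein (Cavia porcellus) with Sigma non-opioid intracellular receptor 1 (Homo sapiens) as the target, read by radioligand binding (a lower number here means a stronger inhibitor, a higher number a weaker inhibitor), compound 1 gives 334 nM, and compound 2 gives 297 nM. The step of a 1.1-fold lower number from compound 1 to compound 2 (0.05 log units; within the scatter) lies within the scatter, so the two values cannot be told apart.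

Compound 3 `O=c1cc(-c2ccccc2)oc2ccc(OCCCCCCN3CCCCC3)cc12` is not yet measured. It differs from compound 2 by piperidin-1-yl in place of 4-(dimethylamino)butyl on a saturated chain carbon, six bonds along the chain from an oxygen on an aromatic ring. Among the compounds with values here, the only measured step concerns chain length alone and was small, while this change closes the nitrogen into a ring and shortens the chain, for which no comparison exists. The expected step of a 1.2-fold lower number from compound 2 to compound 3 (0.07 log units; within the scatter) is therefore modest, with no clear direction. Compound 3 is estimated at 250 nM, within 70 nM to 900 nM.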

Compound 3, half-maximal inhibitory concentration: 101 nM
Estimate against measurement, compound 3: 2.5-fold (0.39 log units) above; the range from low to high includes it.
By their numbers in this assay, from the lowest: compound 3; then compounds 2 and 1 (each within the scatter of the next).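

In this assay the earlier pair of compounds differed only within the scatter, so chain length alone showed no readable effect. Piperidin-1-yl in place of the open-chain dimethylamino end, on a saturated chain carbon six bonds along the chain from an oxygen on an aromatic ring, gives the first steps beyond the scatter, a 2.9-fold lower number from compound 2 to compound 3 (0.47 log units; beyond the scatter) and a 3.3-fold lower number from compound 1 to compound 3 (0.52 log units; beyond the scatter), both modest in size. Nothing measured here explains these steps.

The change closes the amine into a ring and also shortens the chain, and these compounds cannot separate the two. A dimethylamino group at this six-bond position, or piperidin-1-yl on the longer chains, would show which part carries the step, while a morpholine ring would test the ring itself.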